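The source may report more compounds than this note shows. Statements on the series, on what has been measured and on what is new or still open speak of the compounds shown alone.

Compound 1 `COc1ccc(/C=C\C(=O)O)c(OCc2cn(-c3ccc(NC(C)=O)cc3)nn2)c1CC=C(C)C`: in a functional assay on A-431 cells (Homo sapiens) for cytotoxicity, read by MTT assay, with a stated time of 24 h (a higher number here means a weaker inhibitor, a lower number a stronger inhibitor), compound 1 gives 23400 nM.
Compound 2 `COc1ccc(/C=C\C(=O)O)c(OCc2cn(-c3ccc(CO)cc3)nn2)c1CC=C(C)C`: in this assay compound 2 gives 16400 nM.
Compound 3 `COc1ccc(/C=C\C(=O)O)c(OCc2cn(-c3ccccc3C(=O)N3CCC(O)C3)nn2)c1CC=C(C)C`: in this assay compound 3 gives 31500 nM.

All three compounds share the same core and differ only in one peripheral group. Compound 3 gives the highest of the three numbers, but its gap to compound 1 and its gap to compound 2 are both within the scatter, so the three cannot be told apart in this assay; all three are weak inhibitors. Among the measured compounds shown here, the only measured single-point step, a 1.4-fold lower number from compound 1 to compound 2 (0.15 log units; within the scatter), lies within the scatter as well.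

Compound 4 `COc1ccc(/C=C\C(=O)O)c(OCc2cn(-c3ccccc3C#N)nn2)c1CC=C(C)C` differs from compound 3 by cyano in place of (3-hydroxypyrrolidin-1-yl)carbonyl on an aromatic carbon. For the measured compounds named here, no measured step covers this exact exchange; the step from compound 1 to compound 2 concerns a different position and different groups, and it bears on the present change only in a general way, showing that swapping one peripheral group for another left the number in this assay unchanged beyond the scatter. On that basis the step of a 1.4-fold lower number from compound 3 to compound 4 (0.16 log units; within the scatter) is expected to stay within the scatter, with no clear direction. Compound 4 is therefore estimated at 22000 nM in this assay, with a plausible range from 8000 nM to 60000 nM.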

Compound 4, half-maximal inhibitory concentration: 10300 nM
The estimate for compound 4 lay 2.1-fold (0.33 log units) above the measured number; the measured number falls inside the stated range.
By their numbers in this assay, from the lowest: compounds 4, 2, 1 and 3 (each within the scatter of the next, the first and the last beyond it).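

In this assay, among the compounds shown here, cyano in place of (3-hydroxypyrrolidin-1-yl)carbonyl on an aromatic carbon gives a 3.1-fold lower number from compound 3 to compound 4 (0.49 log units; beyond the scatter), the first single-place change here to clear the scatter, so the group at this place can shift the number, though only modestly. Compared across the whole group on the aromatic nitrogen, 2-cyanophenyl in place of 4-acetamidophenyl gives a 2.3-fold lower number from compound 1 to compound 4 (0.36 log units; beyond the scatter), whereas 2-cyanophenyl in place of 4-(hydroxymethyl)phenyl gives a 1.6-fold lower number from compound 2 to compound 4 (0.20 log units; within the scatter), so compound 4 separates from compound 1 and compound 3 but not from compound 2. Nothing shown here offers a cause for these steps.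

For the compounds shown here, with only two groups compared at this aromatic carbon, it remains open whether the lower number reflects the arrival of cyano or simply the departure of the (3-hydroxypyrrolidin-1-yl)carbonyl. A bare hydrogen, a chlorine, an amine or a carboxylic acid at the same place would help separate those two readings, and cyano at another carbon of the ring would show whether its place matters.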